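Hydroxy for chloro on the compound 3 core

This account rests on a few compounds, and the source may have more. Where it says the series, first, only, none or still open, it means among the compounds named here.

Going by the values given here, compound 3 `OC[C@H]1O[C@@H](n2cnc3c(Cl)ncnc32)CS1` is the only member of the series that returns a number in a functional assay on Vero cells (Chlorocebus sabaeus) for inhibition (a lower number here means a stronger inhibitor, a higher number a weaker inhibitor), with 46500 nM. Compound 1 `OC[C@H]1O[C@H](n2cnc3c(O)ncnc32)CS1` gives > 100000 nM in this assay, a limit rather than a number. Compound 2 `O=C1NC(O)C(F)=CN1[C@@H]1CS[C@@H](CO)O1` gives > 100000 nM in this assay, again a limit. The limit thus holds two of the three values shown (the limit of > 100000 nM in this assay, at which 2 of the 3 values shown sit), and compound 3 sits alone below it.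

Compound 4 `OC[C@H]1O[C@@H](n2cnc3c(O)ncnc32)CS1` has not yet been measured in this assay. It differs from compound 3 by hydroxy in place of chloro on an aromatic carbon. Compound 1 carries the same hydroxy group on a core that differs from compound 4 only in its stereochemistry and sits at the limit, so a step beyond the scatter toward weaker inhibition is expected from compound 3 to compound 4, a 2.2-fold higher number from compound 3 to compound 4 (0.33 log units; beyond the scatter). Compound 4 is therefore estimated at 100000 nM, within 30000 nM to 300000 nM, with a fair chance that this assay reports only a limit for it.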

Compound 4, half-maximal inhibitory concentration: > 100000 nM
Compound 4: no number, only a limit; the forecaster's own chance of this, stated with the estimate: 60%; the middle value sits exactly at the limit.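

Hydroxy in place of chloro on this aromatic carbon gives an at least 2.1-fold higher number from compound 3 to compound 4 (0.33 log units; beyond the scatter) in this assay, and this size is only a bound. Of the groups shown at this position, only chloro returns a number, and hydroxy moves the compound to the limit, which now holds most of the series: the limit of > 100000 nM in this assay, at which 3 of the 4 values shown sit.

The configuration on the shared core stays unresolved, since both values are limits and the step between them cannot be read, and this pair isolates one feature only: the fact that compounds 1 and 4 differ only in the configuration as drawn

From the compounds shown here alone, whether an amine or a methoxy group on this aromatic carbon returns a number in this assay stays open, as does the true distance between compound 3 and compound 4. Also open, going by these compounds, is whether chloro keeps a number on the core of compound 1.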